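Taking the pyrrolidine off compound 2

This account rests on a few compounds, and the source may have more. Where it says the series, first, only, none or still open, it means among the compounds named here.

Measured in a functional assay on the whole organism (Abdomen, strain ddY) for inhibition, with Mus musculus as the target, with stated times of 30 min and 20 min; a lower number here means that less compound is needed, a higher number that more compound is needed for the effect:
Compound 1 `CCOc1c(N(CC)CC)cnn(C)c1=O`: 70 mg/kg
Compound 2 `CCOc1c(N2CCCC2)cnn(C)c1=O`: > 100 mg/kg, a limit of the assay
Not yet measured: compound 3 `CCOc1ccnn(C)c1=O`

Compound 2 stands at the limit of > 100 mg/kg in this assay, at which 1 of the 2 values shown sits, so it has no actual number to start from. Compound 3 has hydrogen in place of pyrrolidin-1-yl on an aromatic carbon, opposite the ring nitrogen: hydrogen in place of pyrrolidin-1-yl on an aromatic carbon. Among the measured compounds shown here, only one measured step touches this place, an at least 1.4-fold higher number from compound 1 to compound 2 (0.15 log units; that floor lies within the scatter), with pyrrolidin-1-yl in place of diethylamino. That step exchanges one group for another, whereas the present change removes the group and leaves hydrogen, so it is only a loose guide. For the measured compounds named here, compound 1 at 70 mg/kg holds the only true number in this assay, and no measured compound lacks a group at this place. A modest rise in the number is therefore expected, though a result within the scatter of compound 2 would be no surprise. The expected change is a step that the limit leaves unreadable from compound 2 to compound 3. For compound 3 the estimated value is 130 mg/kg, with an expected range from 60 mg/kg to 300 mg/kg.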

Compound 3, dose for half-maximal effect: > 100 mg/kg
Compound 3: only a limit was reported (the forecaster's own chance of this, stated with the estimate: 60%); the middle value lies beyond the limit too.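

In this assay compound 3 gives > 100 mg/kg, which is a limit of the assay, so leaving hydrogen at this place yields no true number, just as pyrrolidin-1-yl did. The step from pyrrolidin-1-yl to hydrogen cannot be read, and replacing diethylamino with hydrogen gives an at least 1.4-fold higher number from compound 1 to compound 3 (0.15 log units; that floor lies within the scatter), so even the readable comparison does not establish a real difference. Diethylamino therefore remains the only group at this place with a true number, and no size can be put on what any group here contributes, because the data stop at the assay's limit: the limit of > 100 mg/kg in this assay, at which 2 of the 3 values shown sit.

From the compounds shown here alone, whether another amine on this aromatic carbon, such as dimethylamino or dipropylamino, would give a lower number than compound 1 at 70 mg/kg remains open. Also open, going by these compounds, is how far compound 2 and compound 3 lie beyond their limits, and so whether pyrrolidin-1-yl and hydrogen differ at all in this assay.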